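The source may hold more compounds than are shown below. What is called first, only, known or untested is meant among the compounds shown, and "the series" means these compounds.

In a functional assay on VCaP cells (Homo sapiens) for antiproliferative activity, read by CCK-8 assay, with a stated time of 6 days (a higher number here means a weaker inhibitor, a lower number a stronger inhibitor), two compounds of this series have been read so far. Compound 1 `CCN(c1ccc(C#N)c(Cl)c1)c1cc(-c2cnc3ccccc3c2)ccc1C` gives 25300 nM. Compound 2 `CCN(c1ccc(C#N)c(Cl)c1)c1cc(-c2ccco2)ccc1C` gives > 30000 nM, and this is a limit of the assay, not a number. Compound 2 therefore has no exact place on the scale.

Compound 3 `CCN(c1ccc(C#N)c(Cl)c1)c1cc(-n2cccn2)ccc1C` keeps the shared core of compound 2 and alters one group: 1H-pyrazol-1-yl in place of furan-2-yl on an aromatic carbon. In words, it carries 1H-pyrazol-1-yl in place of furan-2-yl on an aromatic carbon, meta to a large group and para to a methyl group. Within the data shown here, no measured pair isolates a change of this kind, so its size must be judged indirectly. Compound 1, which carries a different group at that place, reaches only 25300 nM, so a large gain in this assay is not expected here. The expected move is slight, toward stronger inhibition if it goes anywhere, and may not exceed the scatter. The estimated change is an at least 1.0-fold lower number from compound 2 to compound 3 (0.02 log units; that floor lies within the scatter). For compound 3 the estimated value is 28000 nM, with an expected range from 12000 nM to 60000 nM, and another limit reading is quite possible.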

Compound 3, half-maximal inhibitory concentration: 2340 nM
The estimate for compound 3 lay 12-fold (1.08 log units) above the measured number; measured number outside the range, below it.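

In this assay, the place on the aromatic carbon, meta to a large group and para to a methyl group, turns out to respond strongly to the identity of a five-membered aromatic ring: with the heavy-atom count unchanged, 1H-pyrazol-1-yl in place of furan-2-yl gives an at least 12-fold lower number from compound 2 to compound 3 (1.10 log units; beyond the scatter). Compound 2 stands at a limit of the assay, so this step is only a floor and its full size stays unknown: the limit of > 30000 nM in this assay, at which 1 of the 3 values shown sits.

The earlier compounds shown here gave no sign of this sensitivity, and a ring of this small size now reads stronger than the larger group at the same place, with compound 1 at 25300 nM and compound 3 at 2340 nM.

The compounds shown leave open whether the gain belongs to the two ring nitrogens of 1H-pyrazol-1-yl or to the loss of the ring oxygen of furan-2-yl, since this single step changes both at once. They also leave open how an imidazol-1-yl ring, a pyridin-2-yl ring or a simple amine would read at this place.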